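From 4-bromophenyl to 4-fluorophenyl: working notes

The compounds below may be only part of what the source reports. "The series", "measured", "known", "first", "only" and "open" are said of these compounds alone.

Values so far in a functional assay on HCT-116 cells (Homo sapiens) for cytotoxicity, read by MTT assay, with a stated time of 72 h (a lower number here means a stronger inhibitor, a higher number a weaker inhibitor), are these:
- compound 1 `COc1ccc(S(=O)(=O)c2nc3ccccc3nc2N2CCCC2)cc1` gives > 50000 nM as a limit of the assay
- compound 2 `O=S(=O)(c1ccc(Br)cc1)c1nc2ccccc2nc1N1CCCC1` gives 37700 nM as a measured number

Within the data shown here, compound 2 holds the only actual number in this assay so far. Compound 1 stands at the limit of > 50000 nM in this assay, at which 1 of the 2 values shown sits, and so gives a limit only.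

Compound 3 `O=S(=O)(c1ccc(F)cc1)c1nc2ccccc2nc1N1CCCC1` follows from compound 2 by fluoro in place of bromo on an aromatic carbon and the change is fluoro in place of bromo on an aromatic carbon, para to a large group. Among the measured compounds shown here, the one measured step at this place is an at least 1.3-fold lower number from compound 1 to compound 2 (0.12 log units; that floor lies within the scatter) and it is only a floor, so its true size stays unknown. No step beyond the scatter is therefore expected, and no direction is claimed. The expected step is a 1.1-fold higher number from compound 2 to compound 3 (0.05 log units; within the scatter) as an estimate only. Compound 3 is estimated at 42000 nM with an expected range of 18000 nM to 85000 nM in this reading.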

Compound 3, half-maximal inhibitory concentration: 20600 nM
The estimate for compound 3 lay 2.0-fold (0.31 log units) above the measured number, within the range that was stated.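

In this assay, the change at this position gives a 1.8-fold lower number from compound 2 to compound 3 (0.26 log units; within the scatter), so bromo and fluoro cannot be told apart on these values. Among these compounds, the first step to clear the scatter is an at least 2.4-fold lower number from compound 1 to compound 3 (0.38 log units; beyond the scatter), which puts fluoro ahead of methoxy at this position, whereas the earlier pair gave only a floor within the scatter. Compound 1 stands at a limit, so the true size of that step stays unknown: the limit of > 50000 nM in this assay, at which 1 of the 3 values shown sits.

On these data alone, how an amine or a carboxylic acid in place of the halogen would read in this assay remains open. Also open, as far as these compounds go, is whether a change elsewhere on the shared core would move the number further than any change at this position has so far.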